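Amide substituent step from compound 3 to compound 4

This account rests on a few compounds, and the source may have more. Where it says the series, first, only, none or still open, it means among the compounds named here.

Among the measured compounds shown here, in a functional assay on MDA-MB-231 cells (Homo sapiens) for inhibition, read by MTT assay, with a stated time of 48 h (a higher number here means a weaker inhibitor, a lower number a stronger inhibitor), compound 3 `O=C(NC1CCCCC1)c1[nH]cnc1-c1nc2ccccc2[nH]1` gives 8300 nM and holds the lowest number so far. Compound 1 `N#Cc1cccc(NC(=O)c2[nH]cnc2-c2nc3ccccc3[nH]2)c1` gives 24900 nM here. Compound 2 `CC(C)(C)NC(=O)c1[nH]cnc1-c1nc2ccccc2[nH]1` gives > 40000 nM as a limit of the assay. Compound 4 `O=C(NCc1cccs1)c1[nH]cnc1-c1nc2ccccc2[nH]1` carries (thiophen-2-yl)methyl in place of cyclohexyl on an amide-type nitrogen. For the measured compounds named here, no measured step covers this exchange directly. Compound 1 offers the nearest guide with its aromatic ring: a 3.0-fold lower number from compound 1 to compound 3 (0.48 log units; beyond the scatter) on moving to cyclohexyl. The step of an at least 4.8-fold lower number from compound 2 to compound 3 (0.68 log units; beyond the scatter) also favours cyclohexyl. Leaving cyclohexyl is therefore expected to give back part of that gain, with a higher number in this assay overall. The expected change is an estimated 1.9-fold higher number from compound 3 to compound 4 (0.29 log units; within the scatter) and no more. Compound 4 is estimated at 16000 nM with an expected range from 6500 nM to 38000 nM in this series.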

Compound 4, half-maximal inhibitory concentration: 35100 nM
Beside the measured number, compound 4's estimate is 2.2-fold (0.34 log units) below it, within the range that was stated.
By their numbers in this assay, from the lowest: compound 3; then compounds 1 and 4 (each within the scatter of the next). At a limit, above all of these: compound 2.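

In this assay, the position on the amide-type nitrogen does not tolerate every exchange for cyclohexyl, and (thiophen-2-yl)methyl gives up ground: a 4.2-fold higher number from compound 3 to compound 4 (0.63 log units; beyond the scatter). In place of 3-cyanophenyl, (thiophen-2-yl)methyl gives a 1.4-fold higher number from compound 1 to compound 4 (0.15 log units; within the scatter) and compound 3 stays alone at the low end of the series. In place of tert-butyl, (thiophen-2-yl)methyl gives an at least 1.1-fold lower number from compound 2 to compound 4 (0.05 log units; that floor lies within the scatter) and no more can be read from this exchange. That step rests on a limit and sets no order between the two compounds: the limit of > 40000 nM in this assay, at which 1 of the 4 values shown sits.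

From the compounds shown here alone, whether cyclohexylmethyl on this nitrogen would follow compound 3 or compound 4 stays open, as does the effect of benzyl in place of (thiophen-2-yl)methyl.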